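A few compounds are considered here, and "the series" means these few. Any claim that something is new, unique, unknown or untested is made for them only; others in the source may bear on it.

Measured so far in a functional assay on NCI-H322M cells (Homo sapiens) for inhibition, read by sulforhodamine B assay, with a stated time of 48 h, tested at 100 uM; on this read-out higher numbers stand for a weaker effect at the one concentration tested and lower numbers for a stronger effect:
compound 1 `O=C(Nc1cccc(-n2cc(-c3ccncc3)c(-c3cc(O)cc(Cl)c3)n2)c1)Nc1ccc(Cl)c(C(F)(F)F)c1`: -81%
compound 2 `O=C(Nc1cccc(-n2cc(-c3ccncc3)c(-c3cc(O)cc(Cl)c3)n2)c1)Nc1ccc(Cl)c(Cl)c1`: -24%

Within the data shown here, compound 1 stands lowest of the two numbers in this assay, and the only measured step, a number 57 percentage points higher from compound 1 to compound 2 (beyond the scatter), is a chloro in place of a trifluoromethyl on an aromatic carbon. Compound 3 `COc1cc(Cl)cc(-c2nn(-c3cccc(NC(=O)Nc4ccc(Cl)c(C(F)(F)F)c4)c3)cc2-c2ccncc2)c1` differs from compound 1 in another place: methyl in place of hydrogen on an oxygen on an aromatic ring. Among the measured compounds shown here, no measured step touches the hydroxy, so nothing here bears directly on this change. A small step is expected, a number 16 percentage points higher from compound 1 to compound 3 (beyond the scatter), with wide uncertainty. Compound 3 is estimated at -65%, with a range from -100% to -10%.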

Compound 3, a percentage reported as activity, at one concentration (the size of the read-out at that concentration, not a potency): -22%
Compound 3: middle estimate off by 43 percentage points, on the low side; measured number inside the range.
By their numbers in this assay, from the lowest: compound 1; then compounds 2 and 3 (each within the scatter of the next).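

Hydroxy to methoxy on the 3-chloro-5-hydroxyphenyl group is no neutral change in this assay: it gives a number 59 percentage points higher from compound 1 to compound 3 (beyond the scatter). This position, which the earlier step did not touch, therefore responds as strongly as a large step, and adding one methyl on the oxygen is enough. No available measurement gives a reason for this shift.

Still open, on these data alone, is whether an amine or a fluoro in place of the hydroxy would keep the effect of compound 1. Also open, as far as these compounds go, is whether methoxy has the same effect in the chloro analogue, compound 2.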